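1H-imidazol-1-yl in place of 1H-pyrrol-1-yl at the limit

The compounds below may be only part of what the source reports. "The series", "measured", "known", "first", "only" and "open" are said of these compounds alone.

In a functional assay on ECa-109 cells (Homo sapiens) for antiproliferative activity, read by MTT assay, with a stated time of 48 h (a higher number here means a weaker inhibitor, a lower number a stronger inhibitor), compound 1 (`Cn1cc(C2=C(c3nn(CCCn4cccc4)c4ncccc34)C(=O)NC2=O)c2ccccc21`) gives > 100000 nM as a limit of the assay and not a number. Compound 1 thus stands at the limit of > 100000 nM in this assay, at which 1 of the 3 values shown sits, and offers no exact starting point. Compound 2 (`Cn1cc(C2=C(c3nn(CCCN4CCCCC4)c4ncccc34)C(=O)N(c3cccc4ccccc34)C2=O)c2ccccc21`) gives 1830 nM and compound 3 (`Cn1cc(C2=C(c3nn(CCCN4CCCCC4)c4ncccc34)C(=O)N(c3ccccn3)C2=O)c2ccccc21`) gives 7300 nM on the same scale. Compound 4 (`Cn1cc(C2=C(c3nn(CCCn4ccnc4)c4ncccc34)C(=O)NC2=O)c2ccccc21`) carries the change 1H-imidazol-1-yl in place of 1H-pyrrol-1-yl on a saturated chain carbon, three bonds along the chain from an aromatic nitrogen relative to compound 1, on a saturated chain carbon, three bonds along the chain from an aromatic nitrogen. For the measured compounds named here, no measured step covers this swap. The only one, a 4.0-fold higher number from compound 2 to compound 3 (0.60 log units; beyond the scatter), is a different change, pyridin-2-yl in place of naphthalen-1-yl on an amide-type nitrogen in a ring, and it is modest. Taking it as the sole guide to size, a modest move toward a lower number is expected in this assay and a second limit remains quite possible. The estimate amounts to an expected at least 1.6-fold lower number from compound 1 to compound 4 (0.22 log units; that floor lies within the scatter) in this read-out. For compound 4 the estimated value is 60000 nM with an expected range from 15000 nM to 150000 nM in this assay.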

Compound 4, half-maximal inhibitory concentration: > 100000 nM
Compound 4: only a limit was reported; the forecaster's own chance of this, stated with the estimate: 50%; middle value at least 1.6-fold (0.22 log units) from the limit.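

For the compounds shown here, compound 1 and compound 4 each sit at a limit and not a number, so no step between them can be read in this assay: the limit of > 100000 nM in this assay, at which 2 of the 4 values shown sit. The compounds shown leave open how 1H-imidazol-1-yl and 1H-pyrrol-1-yl compare on the shared core.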